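Iodo added to the anilino ring of compound 3

This account rests on a few compounds, and the source may have more. Where it says the series, first, only, none or still open, it means among the compounds named here.

The three measured compounds share one core and differ only in the group on the amine nitrogen in the ring. Compound 1 `NC(=O)c1c(NC(=O)c2ccccc2Cl)sc2c1CCN(Cc1c(Cl)cccc1Cl)C2` bears 2,6-dichlorophenyl on a saturated chain carbon bound to that nitrogen; in a functional assay on HeLa cells (Homo sapiens) for antiproliferative activity, with a stated time of 24 h (on this read-out lower numbers stand for stronger inhibition and higher numbers for weaker inhibition), compound 1 gives 28800 nM. Compound 2 `NC(=O)c1c(NC(=O)c2ccccc2Cl)sc2c1CCN(Cc1ccc(Cl)cc1Cl)C2` bears 2,4-dichlorophenyl in its place, and in this assay compound 2 gives 21100 nM, a step of a 1.4-fold lower number from compound 1 to compound 2 (0.14 log units; within the scatter). Compound 3 `NC(=O)c1c(NC(=O)c2ccccc2Cl)sc2c1CCN(C(=S)Nc1ccccc1)C2` carries instead a group of 9 heavy atoms (7 carbon, 1 nitrogen, 1 sulfur; one six-membered aromatic ring of carbon only) on that nitrogen; in this assay compound 3 gives 46700 nM, the highest of the three numbers. The step from compound 1 is a 1.6-fold higher number from compound 1 to compound 3 (0.21 log units; within the scatter), that from compound 2 is a 2.2-fold higher number from compound 2 to compound 3 (0.35 log units; beyond the scatter).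

Compound 4 `NC(=O)c1c(NC(=O)c2ccccc2Cl)sc2c1CCN(C(=S)Nc1ccccc1I)C2` differs from compound 3 by iodo in place of hydrogen on an aromatic carbon. Going by the values given here, no measured step adds a substituent to an aromatic carbon within an otherwise fixed group; the only comparison on an aromatic ring, the step from compound 1 to compound 2, stayed within the scatter. No step beyond the scatter is therefore expected, estimated as a 1.2-fold lower number from compound 3 to compound 4 (0.07 log units; within the scatter). Compound 4 is expected to give 40000 nM in this assay, within a range of 13000 nM to 120000 nM.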

Compound 4, half-maximal inhibitory concentration: 29000 nM
For compound 4 the middle estimate is 1.4-fold (0.14 log units) above the measured one, within the range that was stated.
By their numbers in this assay, from the lowest: compounds 2, 1, 4 and 3 (each within the scatter of the next, the first and the last beyond it).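

In this assay, going by these compounds alone, iodo in place of hydrogen on an aromatic carbon, ortho to a large group, gives the first reading of a substituent on the anilino ring: a 1.6-fold lower number from compound 3 to compound 4 (0.21 log units; within the scatter), so this position carries an iodine atom with no step beyond the scatter. Compound 3 stood apart from compound 2 by a 2.2-fold higher number from compound 2 to compound 3 (0.35 log units; beyond the scatter), but the group of 10 heavy atoms on the amine nitrogen in a ring cannot be told from either dichlorophenyl-bearing group, with a 1.4-fold higher number from compound 2 to compound 4 (0.14 log units; within the scatter) and a 1.0-fold higher number from compound 1 to compound 4 (0.00 log units; within the scatter). Nothing available on these compounds explains any of these steps.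

Whether this position can give a step beyond the scatter remains open, as iodo is the only substituent shown on the anilino ring; a methoxy group, an amine or a carboxylic acid in its place would test this. Also open, going by these compounds, is how the other carbons of that ring respond, and whether an oxygen atom in place of the sulfur of the group on the amine nitrogen alters the reading.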